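Benzyl for isopropyl: working notes on the series

The source may hold more compounds than are shown below. What is called first, only, known or untested is meant among the compounds shown, and "the series" means these compounds.

compound 1 `Cc1nc2cc(Cl)c(Cl)cc2n1[C@@H]1O[C@H](CO)[C@@H](O)[C@H]1O`: "not determined" (no result reported)
compound 2 `CC(C)n1c(C(F)(F)F)nc2cc(Cl)c(Cl)cc21`: 81900 nM

In a functional assay on HCT-116 cells (Homo sapiens) for cytotoxicity, read by MTT assay, with a stated time of 48 h (on this read-out higher numbers stand for weaker inhibition of growth and lower numbers for stronger inhibition of growth), compound 2 gives 81900 nM. Within the data shown here, this is the only number so far, so compound 2 cannot yet be ranked against any other compound. Compound 3 `FC(F)(F)c1nc2cc(Cl)c(Cl)cc2n1Cc1ccccc1` carries benzyl in place of isopropyl on an aromatic nitrogen. Among the measured compounds shown here, no measured step informs this change, so the expectation is tentative: a modest move towards stronger growth inhibition, only slightly beyond the scatter. The expected step runs a 2.3-fold lower number from compound 2 to compound 3 (0.37 log units; beyond the scatter). For compound 3 the estimated value is 35000 nM, with an expected range of 9000 nM to 110000 nM.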

Compound 3, concentration for 50% growth inhibition: 8600 nM
Compound 3: the middle estimate sits 4.1-fold (0.61 log units) above what was measured; the measured number lies below the stated range.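

On the aromatic nitrogen, benzyl in place of isopropyl gives a 9.5-fold lower number from compound 2 to compound 3 (0.98 log units; beyond the scatter) in this assay, so this position responds to the change of group by more than the scatter. An added six-membered aromatic ring of carbon only is therefore tolerated here and goes with stronger inhibition of growth. No supporting measurement bears on the reason for this step.

On these data alone, whether the aromatic ring itself matters remains open; a cyclohexylmethyl group on the same nitrogen would test that. A phenethyl group, or an amine on the benzyl ring, also remains untested in the compounds shown.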